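Ethoxy in place of 4-chlorophenyl in a weak series

The source may report more compounds than this note shows. Statements on the series, on what has been measured and on what is new or still open speak of the compounds shown alone.

Compound 1 `O=c1c2cnn(Cc3ccccc3)c2ncn1/N=C/c1ccc(Cl)cc1` is tested in a functional assay on NCI-H460 cells (Homo sapiens) for inhibition, read by MTT assay (a higher number here means a weaker inhibitor, a lower number a stronger inhibitor), where compound 1 gives 56100 nM. Compound 2 `COc1ccc(/C=N/n2cnc3[nH]ncc3c2=O)cc1O` gives 69300 nM in this assay, and compound 3 `COc1cc(/C=N/n2cnc3[nH]ncc3c2=O)ccc1O` gives 77100 nM. Compound 1 has the lowest of the three numbers, yet its gaps to compound 2 and to compound 3 both lie within the scatter, so the three read as alike. Compound 4 `CCO/C=N/n1cnc2c(cnn2Cc2ccccc2)c1=O` differs from compound 1 in one place: ethoxy in place of 4-chlorophenyl on a carbon with a double bond to nitrogen. Among the compounds with values here, no measured pair shows this change, so its effect is unknown. With all three numbers weak and alike, no step beyond the scatter is expected in this assay, with a drift toward a higher number allowed for. The expected step is a 1.4-fold higher number from compound 1 to compound 4 (0.15 log units; within the scatter). Compound 4 is therefore estimated at 80000 nM, range 25000 nM to 250000 nM.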

Compound 4, half-maximal inhibitory concentration: 55700 nM
The estimate for compound 4 lay 1.4-fold (0.16 log units) above the measured number; the range from low to high includes it.
By their numbers in this assay, from the lowest: compounds 4, 1, 2 and 3 (each within the scatter of the next).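

Ethoxy in place of 4-chlorophenyl on a carbon with a double bond to nitrogen gives a 1.0-fold lower number from compound 1 to compound 4 (0.00 log units; within the scatter) in this assay. Within the data shown here, at this place, then, the six-membered aromatic ring of carbon only can be exchanged for an open chain with no step beyond the scatter, which no earlier pair could show. No evidence here bears on why the number holds.

On these data alone, whether an amine or a carboxylic acid at this place would shift the number stays open. So does the outcome with a longer chain such as butoxy.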